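Swapping the phenyl group on the shared core

This account rests on a few compounds, and the source may have more. Where it says the series, first, only, none or still open, it means among the compounds named here.

In a functional assay on SW-620 cells (Homo sapiens) for cytotoxicity, read by sulforhodamine B assay, with a stated time of 48 h (on this read-out higher numbers stand for weaker inhibition and lower numbers for stronger inhibition), compound 1 `C[C@H]1CC[C@@H]2[C@@H](OC(=O)[C@]23CC(c2ccc(Cl)cc2)=NO3)[C@]2(C)C(=O)C=C[C@@]12O` gives 51000 nM and compound 2 `C[C@H]1CC[C@@H]2[C@@H](OC(=O)[C@]23CC(c2ccc(O)cc2)=NO3)[C@]2(C)C(=O)C=C[C@@]12O` gives 89000 nM while compound 3 `COc1ccc(C2=NO[C@]3(C2)C(=O)O[C@@H]2[C@H]3CC[C@H](C)[C@]3(O)C=CC(=O)[C@@]23C)cc1OC` gives 86000 nM as its number. Compound 3 therefore stands within the scatter of both compound 1 and compound 2.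

Going to compound 4 `Cc1ccccc1C1=NO[C@]2(C1)C(=O)O[C@@H]1[C@H]2CC[C@H](C)[C@]2(O)C=CC(=O)[C@@]12C` puts 2-methylphenyl in place of 3,4-dimethoxyphenyl on a carbon with a double bond to nitrogen and leaves the rest of the core as it is.

The measured steps bearing on this change the same substituent: a 1.7-fold higher number from compound 1 to compound 2 (0.24 log units; within the scatter) and a 1.7-fold higher number from compound 1 to compound 3 (0.23 log units; within the scatter) and a 1.0-fold lower number from compound 2 to compound 3 (0.01 log units; within the scatter) all stay within the scatter. For the measured compounds named here, no measured compound carries 2-methylphenyl, so the data hold no direct precedent for it. Given those three flat steps, no shift beyond the scatter is expected in this assay for this change. The estimated step is a 1.2-fold lower number from compound 3 to compound 4 (0.09 log units; within the scatter) and is expected to stay within the scatter. Compound 4 is estimated at 70000 nM with an expected range of 35000 nM to 135000 nM for its measurement.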

Compound 4, half-maximal inhibitory concentration: 5000 nM
Estimate against measurement, compound 4: 14-fold (1.15 log units) above; the whole stated range lies above it.
By their numbers in this assay, from the lowest: compound 4; then compounds 1, 3 and 2 (each within the scatter of the next).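

In this assay the aryl group on the carbon with a double bond to nitrogen proves able to move the number: 2-methylphenyl gives a 17-fold lower number from compound 3 to compound 4 (1.24 log units; beyond the scatter) and an 18-fold lower number from compound 2 to compound 4 (1.25 log units; beyond the scatter) and also a 10-fold lower number from compound 1 to compound 4 (1.01 log units; beyond the scatter). The 4-chlorophenyl, 4-hydroxyphenyl and 3,4-dimethoxyphenyl groups had stayed within the scatter of one another, so their flat steps did not carry over to this fourth group. No measurement at hand accounts for the large shift.

The compounds shown leave open whether the shift depends on the methyl itself or on the place it holds in 2-methylphenyl. A plain phenyl group would test the need for the methyl, and an ethyl or an aminomethyl group in its stead would test how much change that place tolerates.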